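A Carboxybenzyloxy Group on the Other Benzyl Arm

A few compounds are considered here, and "the series" means these few. Any claim that something is new, unique, unknown or untested is made for them only; others in the source may bear on it.

Compound 1 `O=C(NCc1ccccc1)[C@@H]1CCC(=O)N1Cc1ccccc1` is the parent of this small set. In an assay on HEK293 cells for inhibition of Ataxin-2 (Mus musculus), read by fluorescence and Amplex Red (a higher number here means a weaker inhibitor, a lower number a stronger inhibitor), compound 1 gives > 5000 nM, which is a limit of the assay rather than a number. On the numbers shown, compound 1 therefore stands at the limit of > 5000 nM in this assay, at which 1 of the 2 values shown sits. Compound 2 `O=C(O)c1ccc(COc2ccc(CNC(=O)[C@@H]3CCC(=O)N3Cc3ccccc3)cc2)cc1` adds (4-carboxybenzyl)oxy in place of hydrogen on an aromatic carbon, and in this assay compound 2 gives 4500 nM; the step of an at least 1.1-fold lower number from compound 1 to compound 2 (0.04 log units; that floor lies within the scatter) lies within the scatter.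

Compound 3 `O=C(O)c1ccc(COc2ccc(CN3C(=O)CC[C@H]3C(=O)NCc3ccccc3)cc2)cc1` differs from compound 1 by (4-carboxybenzyl)oxy in place of hydrogen on an aromatic carbon, the same entering group as in compound 2, though the structures show it in a different position. Within the data shown here, the only measured step that bears on this change is the one from compound 1 to compound 2, which stayed within the scatter. No step beyond the scatter is therefore expected, a number no higher from compound 1 to compound 3 (the limit leaves the size open), in this assay. Compound 3 is estimated at 5000 nM, between 2500 nM and 10000 nM, and may again be reported only as a limit.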

Compound 3, half-maximal inhibitory concentration: > 5000 nM
Compound 3 gave a limit, no number; the forecaster's own chance of this, stated with the estimate: 50%; the middle value sits exactly at the limit.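

In this assay compound 3 gives > 5000 nM, which is a limit and not a number. Among these compounds, no step between compound 1 and compound 3 can be read, as both stand at the same limit: the limit of > 5000 nM in this assay, at which 2 of the 3 values shown sit. The compounds shown leave open whether the (4-carboxybenzyl)oxy group in compound 3 changes the value of compound 1 at all.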